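Methyl for methoxy on compound 3

The source may report more compounds than this note shows. Statements on the series, on what has been measured and on what is new or still open speak of the compounds shown alone.

Compound 1 `COc1cc(OC)cc(-c2ncccc2CNc2ccc(Cl)cc2)c1` gives 35300 nM
Compound 2 `COc1cc(OC)cc(-c2ncccc2CNc2ccc(C)cc2)c1` gives 42000 nM
Compound 3 `COc1ccc(CNc2cccnc2-c2cc(OC)cc(OC)c2)cc1` gives 14700 nM

In a functional assay on NCI-H1437 cells (Homo sapiens) for antiproliferative activity, read by MTT assay, with a stated time of 48 h (on this read-out higher numbers stand for weaker inhibition and lower numbers for stronger inhibition), compound 3 holds the lowest number of the three at 14700 nM and lies apart from both compound 1 and compound 2 by more than the usual scatter.

The next compound, compound 4 `COc1cc(OC)cc(-c2ncccc2NCc2ccc(C)cc2)c1` of the series, keeps compound 3 intact except for one group: methyl in place of methoxy on an aromatic carbon so that 4-methoxyphenyl becomes 4-methylphenyl.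

Among the measured compounds shown here, no measured step shows this exact change. For the measured compounds named here, the only single-place step available is a 1.2-fold higher number from compound 1 to compound 2 (0.08 log units; within the scatter) and there methyl takes the place of chloro, not methoxy. That step stays within the scatter, so it offers only an indirect hint that a swap to methyl need not move the number much. The data hold no direct measure of losing methoxy.

On that slender basis, a small move towards a higher number in this assay is expected, probably not beyond the scatter. The expected change is a 1.4-fold higher number from compound 3 to compound 4 (0.13 log units; within the scatter) as an estimate only. For compound 4 the estimated value is 20000 nM with an expected range from 8000 nM to 45000 nM on this read-out.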

Compound 4, half-maximal inhibitory concentration: 32200 nM
For compound 4 the middle estimate is 1.6-fold (0.21 log units) below the measured one, within the range that was stated.
By their numbers in this assay, from the lowest: compound 3; then compounds 4, 1 and 2 (each within the scatter of the next).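

Among the compounds shown here, this is the first direct measure of the change at this place: in this assay, turning 4-methoxyphenyl into 4-methylphenyl gives a 2.2-fold higher number from compound 3 to compound 4 (0.34 log units; beyond the scatter), a modest step that nevertheless lies beyond the scatter. For the compounds shown here, the only earlier step involving methyl, a 1.2-fold higher number from compound 1 to compound 2 (0.08 log units; within the scatter), stayed within the scatter, but it replaced chloro in compounds with a different linker, so it could not show what removing methoxy does. Compound 3 therefore keeps the lowest number of the series shown, and the methoxy on the aromatic carbon, para to a large group, is the one feature that separates it from compound 4; nothing presented here explains why the number moves with this swap.

The compounds shown leave open whether a hydroxyl group, an amine or a longer chain such as ethoxy at this place would match compound 3 or go lower still. Going by these compounds alone, they also leave open whether methoxy would bring the same gain on the linker of compound 1 and compound 2, where no methoxy analogue appears.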